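The source may report more compounds than this note shows. Statements on the series, on what has been measured and on what is new or still open speak of the compounds shown alone.

Working notes on the series. Two members of this set have numbers in an assay on CHO-K1 cells for displacement of a labelled ligand from adenosine receptor A1 (Homo sapiens), read by scintillation counting, with a stated time of 60 min; on this read-out higher numbers stand for weaker inhibition and lower numbers for stronger inhibition. Compound 1, `Nc1nc(N/N=C/c2cccc(OCc3ccccc3)c2)nc2c1ncn2[C@@H]1O[C@H](CO)[C@@H](O)[C@H]1O`, gives 13 nM in this assay. Compound 2, `CCOc1cc(/C=N/Nc2nc(N)c3ncn([C@@H]4O[C@H](CO)[C@@H](O)[C@H]4O)c3n2)ccc1O`, gives 6940 nM in this assay, the highest of the two numbers shown, and its only comparator is compound 1, whose number is far lower, a gap well beyond the scatter. Going by the values given here, no step between members that differ in one place is available, so nothing is known yet about how single changes at the carbon with a double bond to nitrogen move this read-out.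

Compound 3, `Nc1nc(N/N=C/C2CCCC2)nc2c1ncn2[C@@H]1O[C@H](CO)[C@@H](O)[C@H]1O`, has not been measured. It differs from compound 2 as follows: cyclopentyl in place of 3-ethoxy-4-hydroxyphenyl on a carbon with a double bond to nitrogen. Because compound 1 reaches 13 nM with no hydrogen-bond donor on the group at that carbon, the step is expected to go downward, estimated at a 9.9-fold lower number from compound 2 to compound 3 (1.00 log units; beyond the scatter). Compound 3 is expected to give about 700 nM in this assay, within 80 nM to 6000 nM.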

Compound 3, inhibition constant: 5.6 nM
Compound 3: the middle estimate sits 130-fold (2.10 log units) above what was measured; the measured number lies below the stated range.
By their numbers in this assay, from the lowest: compound 3; then compound 1; then compound 2.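

Going by these compounds alone, replacing 3-ethoxy-4-hydroxyphenyl with cyclopentyl on a carbon with a double bond to nitrogen gives, in this assay, a 1200-fold lower number from compound 2 to compound 3 (3.09 log units; beyond the scatter), the first step that differs in one place, so a change at this position alone can move the number by a large margin. A six-membered aromatic ring is not required here for a low number: compound 3, with one five-membered non-aromatic ring of carbon only, gives 5.6 nM. Nothing at hand explains the size of this step.

The step changes the ring, the ethoxy and the hydroxy together, so the compounds shown leave open which of these parts accounts for it. Also open, as far as these compounds go, is how the number responds at this position to cyclohexyl, a straight pentyl chain or a piperidinyl ring.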